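Halogen swaps leave toxicity flat; a furan ring enters

The compounds below may be only part of what the source reports. "The series", "measured", "known", "first", "only" and "open" are said of these compounds alone.

Three compounds sharing one core were tested for cytotoxicity. Compound 1 `COc1cc(CC(O)c2ccc(-c3ccc(F)cc3)cc2)c([N+](=O)[O-])cc1OC` gives 4500 nM in an ADME assay on HeLa Rh cells (Homo sapiens) for cytotoxicity, read by microscopy; on this read-out lower numbers stand for higher toxicity in this test and higher numbers for lower toxicity in this test; compound 2 `COc1cc(CC(O)c2ccc(-c3ccc(Cl)cc3)cc2)c([N+](=O)[O-])cc1OC` gives 4100 nM and compound 3 `COc1cc(CC(O)c2ccc(-c3ccc(Br)cc3)cc2)c([N+](=O)[O-])cc1OC` gives 4300 nM. Compound 1 shows the highest number of the three, but the margin is small: a 1.1-fold lower number from compound 1 to compound 2 (0.04 log units; within the scatter) and a 1.0-fold lower number from compound 1 to compound 3 (0.02 log units; within the scatter), while a 1.0-fold higher number from compound 2 to compound 3 (0.02 log units; within the scatter). Exchanging one halogen for another on the outer ring therefore leaves the read-out unmoved.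

Compound 4 `COc1cc(CC(O)c2ccc(-c3ccoc3)cc2)c([N+](=O)[O-])cc1OC` takes a different route from compound 1: furan-3-yl in place of 4-fluorophenyl on an aromatic carbon. Among the compounds with values here, none of the measured steps tests the loss of the whole ring, so they bear on it only indirectly, showing that the outer position tolerates variation without a shift beyond the scatter. On that basis compound 4 is expected to sit close to compound 1, with no change at the digits printed from compound 1 to compound 4 (within the scatter) as the estimated step. Compound 4 is estimated at 4500 nM, within a range of 2000 nM to 10000 nM.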

Compound 4, half-maximal cytotoxic concentration: 5300 nM
For compound 4 the middle estimate is 1.2-fold (0.07 log units) below the measured one, within the range that was stated.
By their numbers in this assay, from the lowest: compounds 2, 3, 1 and 4 (each within the scatter of the next).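

The outer position accepts more than a halogen swap on the ring: in this assay the whole 4-fluorophenyl can give way to furan-3-yl (a 1.2-fold higher number from compound 1 to compound 4 (0.07 log units; within the scatter)), and the same holds against the bromo analogue (a 1.2-fold higher number from compound 3 to compound 4 (0.09 log units; within the scatter)) and the chloro analogue (a 1.3-fold higher number from compound 2 to compound 4 (0.11 log units; within the scatter)). A five-membered aromatic ring with 1 hetero atom and 1 hydrogen-bond acceptor thus stands in for a six-membered aromatic ring of carbon only, with every step inside the scatter. No supporting data offer an account of this tolerance.

Every outer group shown is an aromatic ring, so what an amine, a carboxylic acid or a longer alkyl chain would do in this place remains open. All four compounds also share one core, so the part played by its nitro group or hydroxyl group cannot be judged from them.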